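A chlorine-to-fluorine swap carried onto a larger core

The source may report more compounds than this note shows. Statements on the series, on what has been measured and on what is new or still open speak of the compounds shown alone.

Compound 1 `COC(=O)[C@@]1(C)CCC=C2[C@@H]1CC[C@@H](C)[C@]2(C)Cc1c(C)[nH]c2ccc(Cl)cc12` and compound 2 `COC(=O)[C@@]1(C)CCC=C2[C@@H]1CC[C@@H](C)[C@]2(C)Cc1c(C)[nH]c2ccc(F)cc12` share a core and differ in one place. In a functional assay on SW1573 cells (Homo sapiens) for inhibition, read by sulforhodamine B assay, with a stated time of 48 h (on this read-out lower numbers stand for stronger inhibition of growth and higher numbers for weaker inhibition of growth), compound 1 gives 14000 nM, and compound 2 gives 12000 nM. The change between them is fluoro in place of chloro on an aromatic carbon and it made a 1.2-fold lower number from compound 1 to compound 2 (0.07 log units; within the scatter), so the two values cannot be told apart here.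

Compound 3 `COC(=O)[C@@]1(C)CC[C@@H]2C3=C1CC[C@@H](C)[C@]3(C)C[C@@H]1c3cc(Cl)ccc3N[C@H]21` is built on a different core; the difference between the two cores is not broken down here. In this assay compound 3 gives 38000 nM, the highest of the three numbers, beyond the scatter from the others.

Compound 4 `COC(=O)[C@@]1(C)CC[C@@H]2C3=C1CC[C@@H](C)[C@]3(C)C[C@@H]1c3cc(F)ccc3N[C@H]21` is not yet measured. It differs from compound 3 by fluoro in place of chloro on an aromatic carbon. The place of the change is not the same word for word as before: in compound 3 the ring is part of a fused or bridged system of five rings, while in compound 1 it is part of a fused or bridged system of two rings, so this is the same kind of change rather than the same change. The expectation for compound 4 in this assay is a step of a 1.2-fold lower number from compound 3 to compound 4 (0.07 log units; within the scatter), beside the earlier 1.2-fold lower number from compound 1 to compound 2 (0.07 log units; within the scatter), resting on the near-identity of compound 1 and compound 2 in that assay. Compound 4 is therefore estimated at 32000 nM, expected to fall between 15000 nM and 70000 nM.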

Compound 4, concentration for 50% growth inhibition: 27000 nM
Beside the measured number, compound 4's estimate is 1.2-fold (0.07 log units) above it; the measured number falls inside the stated range.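

In this assay, fluoro in place of chloro on the larger core gives a 1.4-fold lower number from compound 3 to compound 4 (0.15 log units; within the scatter), so compound 3 and compound 4 cannot be told apart, just as compound 1 and compound 2 could not. Set side by side, the swap reads the same on both cores: the same change on two cores in this assay, a 1.2-fold lower number (0.07 log units; within the scatter) from compound 1 to compound 2 and a 1.4-fold lower number (0.15 log units; within the scatter) from compound 3 to compound 4, 1.2-fold (0.08 log units) apart, within the scatter of two such steps This shows that the swap left the number within the scatter on each of these two cores, but what carries over is an absence of any measurable change rather than a real effect, and two pairs say nothing about how the swap would behave on a third core or at another place on the ring.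

Chloro and fluoro are the only groups shown at this aromatic carbon, so it remains open whether a larger or quite different group there, such as a methoxy group, a nitrile or an amine, would move the number beyond the scatter. The methyl ester is also the same in all four compounds, which leaves open what a carboxylic acid or an amide in its place would do to growth inhibition on either core.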